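Replacing phenylsulfanyl with methoxy on the butyl chain

This account rests on a few compounds, and the source may have more. Where it says the series, first, only, none or still open, it means among the compounds named here.

Compound 1 `CCc1nc2ccccc2n1CCCCOc1cccc(Cl)c1`: 22 uM
Compound 2 `CCc1nc2ccccc2n1CCCCOc1ccc(C)c(Cl)c1`: 14 uM
Compound 3 `CCc1nc2ccccc2n1CCCCSc1ccccc1`: 31 uM

Three compounds sharing the same core have been examined in an ADME assay on Vero cells (Chlorocebus sabaeus) for cytotoxicity, read by luminescence, with a stated time of 2 days; a higher number here means that more compound is tolerated, a lower number that less compound is tolerated. Compound 1 gives 22 uM, compound 2 gives 14 uM and compound 3 gives 31 uM. Compound 3 therefore stands highest of the three numbers shown; its nearest neighbour is compound 1, whose number lies within the scatter of that of compound 3, while compound 2 lies furthest away, beyond the scatter.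

Compound 4 `CCc1nc2ccccc2n1CCCCOC` has not yet been measured in this assay. It differs from compound 3 in one place: methoxy in place of phenylsulfanyl on a saturated chain carbon, four bonds along the chain from an aromatic nitrogen. Among the compounds with values here, the only measured step between neighbouring compounds is a 1.6-fold lower number from compound 1 to compound 2 (0.20 log units; within the scatter), a change of a methyl on an aromatic carbon that leaves the chain and its terminal group untouched. Within the data shown here, no measured pair in this set exchanges a phenylsulfanyl for a methoxy, so no step bears closely on the change from compound 3 to compound 4, and the one available step lies within the scatter.

With that in mind, compound 4 is expected to fall near compound 3, the expected step being a 1.5-fold higher number from compound 3 to compound 4 (0.16 log units; within the scatter). Among the measured compounds shown here, the estimate for compound 4 in this assay is 45 uM, with a range from 20 uM to 120 uM, reflecting that no comparable measured step is available.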

Compound 4, half-maximal toxic concentration: > 50 uM
Compound 4 gave a limit, no number (the forecaster's own chance of this, stated with the estimate: 25%); at least 1.1-fold (0.04 log units) between middle value and limit.
By their numbers in this assay, from the lowest: compounds 2, 1 and 3 (each within the scatter of the next, the first and the last beyond it). At a limit, above all of these: compound 4.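

With methoxy in place of phenylsulfanyl on a saturated chain carbon, four bonds along the chain from an aromatic nitrogen, this assay gives compound 4 a limit and not a number: the limit of > 50 uM in this assay, at which 1 of the 4 values shown sits. The exchange with compound 3 gives an at least 1.6-fold higher number from compound 3 to compound 4 (0.20 log units; that floor lies within the scatter), so this step alone does not separate the two compounds, although it shows that this position can lose the six-membered aromatic ring with no fall in the number. Within the data shown here, the clearer gaps appear where methyl replaces 3-chlorophenyl, with an at least 2.2-fold higher number from compound 1 to compound 4 (0.35 log units; beyond the scatter), and where it replaces 3-chloro-4-methylphenyl, with an at least 3.5-fold higher number from compound 2 to compound 4 (0.55 log units; beyond the scatter), whereas the earlier compounds all kept an aromatic ring at the end of the chain and offered only a step on that ring.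

As far as these compounds go, how far the true value of compound 4 lies past its limit remains open, and with it the full size of all three steps. The compounds shown also leave open how a terminal amine, a carboxylic acid or a longer chain in this position would read in this assay.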